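The source may hold more compounds than are shown below. What is called first, only, known or untested is meant among the compounds shown, and "the series" means these compounds.

Measured so far in a functional assay on HOP-62 cells (Homo sapiens) for inhibition, read by sulforhodamine B assay, with a stated time of 48 h; a lower number here means that less compound is tolerated, a higher number that more compound is tolerated:

Compound 1, `Nc1cc(N)c2nc(-c3ccccc3)c(NCc3ccc(Cl)c(Cl)c3)nc2c1`, gives 64600 nM.
Compound 2, `Nc1cc(N)c2nc(-c3ccccc3)c(Oc3ccc(F)cc3)nc2c1`, gives only a limit of the assay, < 100000 nM.
Compound 3, `COc1ccc(CNc2nc3cc(N)cc(N)c3nc2-c2ccccc2)cc1OC`, gives 64600 nM.

Compound 2 therefore stands on the numbers only as a limit, and that limit is where one of the three values sits (the limit of < 100000 nM in this assay, at which 1 of the 3 values shown sits). Among the measured compounds shown here, compounds 1 and 3 both give the same reading, and the one measured step between them, no change at the digits printed from compound 1 to compound 3 (within the scatter), lies within the scatter.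

Compound 4, `COc1ccc(Sc2nc3cc(N)cc(N)c3nc2-c2ccccc2)cc1`, has not yet been measured. It differs from compound 2 by (4-methoxyphenyl)sulfanyl in place of 4-fluorophenoxy on an aromatic carbon. For the measured compounds named here, no measured step changes the group on this aromatic carbon, so the step from compound 1 to compound 3 bears on it only loosely: it shows that exchanging one aryl group for another on the shared core left this assay unchanged. On that basis the expected step, a step that the limit leaves unreadable from compound 2 to compound 4, is no larger than the scatter, with no direction to it. Compound 4 is thus estimated at 65000 nM, in a range from 25000 nM to 100000 nM.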

Compound 4, concentration lethal to 50% of the cells: < 100000 nM
Compound 4 gave a limit, no number; the forecaster's own chance of this, stated with the estimate: 40%; the middle value is on the limit's open side.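

Among the compounds shown here, compound 2 and compound 4 both stand only as limits of the assay in this assay, so no step between them can be read: the limit of < 100000 nM in this assay, at which 2 of the 4 values shown sit.

The compounds shown leave open whether (4-methoxyphenyl)sulfanyl in place of 4-fluorophenoxy on this aromatic carbon changes the reading at all, and in which direction.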